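The source may hold more compounds than are shown below. What is called first, only, known or untested is meant among the compounds shown, and "the series" means these compounds.

Compound 2 `Cc1ccccc1C(=O)Nc1ccc(C(=O)N2CCCC(NCCCN3CCCCC3)c3cc(Cl)ccc32)c(C)c1` stands highest of the two numbers in an ADME assay on the whole organism (Mus musculus, strain C57BL/6) for metabolic stability, read by LC-MS, at a dose of 2 mg/kg by the subcutaneous route (a lower number here means that the compound disappears faster, a higher number that the compound lasts longer), where compound 2 gives 3.9 h; compound 1 `Cc1ccccc1C(=O)Nc1ccc(C(=O)N2CCCC(NCCCc3ccncc3)c3cc(Cl)ccc32)c(C)c1` gives 0.533 h, and the step of a 7.3-fold higher number from compound 1 to compound 2 (0.86 log units; beyond the scatter) accompanied the switch to piperidin-1-yl. Compound 3 `Cc1ccccc1C(=O)Nc1ccc(C(=O)N2CCCC(NCCC(=O)N3CCOCC3)c3cc(Cl)ccc32)c(C)c1` differs from compound 2 by (morpholin-4-yl)carbonyl in place of (piperidin-1-yl)methyl on a saturated chain carbon, two bonds along the chain from an amine nitrogen. For the measured compounds named here, no measured step tests this exchange directly; only the step of a 7.3-fold higher number from compound 1 to compound 2 (0.86 log units; beyond the scatter) shows that swapping the group at this end of the chain moved the half-life beyond the scatter. A drop is therefore expected, the step of a 3.3-fold lower number from compound 2 to compound 3 (0.51 log units; beyond the scatter). The half-life of compound 3 in this assay is estimated at 1.2 h, within 0.4 h to 3.5 h.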

Compound 3, half-life in the Mus musculus assay: 0.29 h
Beside the measured number, compound 3's estimate is 4.1-fold (0.62 log units) above it, and the stated range ends above it.
By their numbers in the Mus musculus assay, from the lowest: compounds 3 and 1 (each within the scatter of the next); then compound 2.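

In the Mus musculus assay compound 1 gives 0.533 h, compound 2 gives 3.9 h and compound 3 gives 0.29 h. Swapping the chain end in the Mus musculus assay costs compound 2 its lead (a 13-fold lower number from compound 2 to compound 3 (1.13 log units; beyond the scatter)), while the other comparison stays within the scatter (a 1.8-fold lower number from compound 1 to compound 3 (0.26 log units; within the scatter)), so among these three chain ends only the piperidin-1-yl end stands apart. In a physicochemical assay for solubility, measured as thermodynamic solubility, with a stated time of 24 h (a lower number here means a less soluble compound, a higher number a more soluble compound), compound 2 gives 2.3 ug/mL and compound 3 gives 2.3 ug/mL, and the same change leaves the number unmoved (no change at the digits printed from compound 2 to compound 3 (within the scatter)). Nothing available here bears on why the half-life fell.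

From the compounds shown here alone, the carbonyl and the morpholine ring oxygen enter together, and it stays open which of them goes with the drop. A (morpholin-4-yl)methyl or (piperidin-1-yl)carbonyl end would separate the two.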